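A few compounds are considered here, and "the series" means these few. Any claim that something is new, unique, unknown or untested is made for them only; others in the source may bear on it.

In an assay on a protein complex for displacement of a labelled ligand from CDK8/Cyclin C (Homo sapiens), read by TR-FRET, with a stated time of 1 h (a lower number here means a stronger inhibitor, a higher number a weaker inhibitor), the three measured compounds gave the following numbers:

compound 1 `CNc1nccc(N2CC[C@H](NC(=O)Nc3ccc(Cl)c(C(F)(F)F)c3)C2)n1`: 10.1 nM
compound 2 `O=C(Nc1ccc(Cl)c(C(F)(F)F)c1)N[C@H]1CCN(c2ccc3nncn3n2)C1`: 4.2 nM
compound 3 `CCNc1nccc(N2CC[C@H](NC(=O)Nc3ccc(Cl)c(C(F)(F)F)c3)C2)n1`: 8.9 nM

Compound 1 has the highest number of the three in this assay. Its nearest neighbour is compound 3, where a methyl enters on the saturated chain carbon bound to the aromatic nitrogen; the step of a 1.1-fold lower number from compound 1 to compound 3 (0.05 log units; within the scatter) stays within the scatter. The furthest is compound 2, where the whole group on the ring amine nitrogen is exchanged, and the step of a 2.4-fold lower number from compound 1 to compound 2 (0.38 log units; beyond the scatter) is modest but real. Likewise a 2.1-fold higher number from compound 2 to compound 3 (0.33 log units; beyond the scatter) is modest.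

Compound 4 `CNc1nccc(N2CC[C@H](NC(=O)Nc3ccc(CN4CCCC4)c(C(F)(F)F)c3)C2)n1` differs from compound 1 at the other end of the molecule: (pyrrolidin-1-yl)methyl in place of chloro on an aromatic carbon. For the measured compounds named here, none of the measured steps touches this part of the structure, so they give no direct guide; all three keep the chloro and trifluoromethyl ring unchanged. With that blank, a modest rise in the number is expected for compound 4, with a wide range: a 2.5-fold higher number from compound 1 to compound 4 (0.39 log units; beyond the scatter), giving an estimate of 25 nM in this assay, between 6 nM and 100 nM.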

Compound 4, half-maximal inhibitory concentration: 157 nM
The estimate for compound 4 lay 6.3-fold (0.80 log units) below the measured number, and the stated range ends below it.
By their numbers in this assay, from the lowest: compound 2; then compounds 3 and 1 (each within the scatter of the next); then compound 4.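

For the compounds shown here, the position that carries the chloro on the aromatic ring proves highly sensitive in this assay: a 16-fold higher number from compound 1 to compound 4 (1.19 log units; beyond the scatter) is a far larger step than any seen among the earlier compounds, which all keep that chloro. At this place, a single chlorine atom gives way to (pyrrolidin-1-yl)methyl, a group of six heavy atoms with a non-aromatic ring and a hydrogen-bond acceptor, and the inhibitor becomes much weaker. No available evidence accounts for this rise.

With only this one replacement, the loss cannot be assigned to the removal of the chloro, the added ring, the added nitrogen or the overall size of the new group. A fluoro, a methyl or an open-chain dimethylaminomethyl group at the same place would help separate these possibilities.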